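Replacing a Methylsulfanyl Group with Quinolin-3-yl

A few compounds are considered here, and "the series" means these few. Any claim that something is new, unique, unknown or untested is made for them only; others in the source may bear on it.

Within the data shown here, compound 2 `CCOC(=O)c1cnc(SC)nc1NN1C(=O)C=C(C)C1=O` gives 200 nM in a functional assay on Jurkat cells for inhibition of nuclear factor NF-kappa-B complex (Homo sapiens) (on this read-out higher numbers stand for weaker inhibition and lower numbers for stronger inhibition), the lowest of the two numbers measured so far, while compound 1 `CCOC(=O)c1cnc(C(F)(F)F)nc1NN1C(=O)C=C(C)C1=O` gives 1000 nM. Among the measured compounds shown here, the one measured step, a 5.0-fold lower number from compound 1 to compound 2 (0.70 log units; beyond the scatter), shows that exchanging the group on this aromatic carbon does move the number. Compound 3 `CCOC(=O)c1cnc(-c2cnc3ccccc3c2)nc1NN1C(=O)C=C(C)C1=O` carries a larger exchange at the same place: quinolin-3-yl in place of methylsulfanyl on an aromatic carbon. For the measured compounds named here, no measured step involves a group resembling quinolin-3-yl, so the direction is open. The step is expected to be a 1.5-fold higher number from compound 2 to compound 3 (0.18 log units; within the scatter). Compound 3 is estimated at 300 nM, probably between 50 nM and 2000 nM.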

Compound 3, half-maximal inhibitory concentration: 6000 nM
The estimate for compound 3 lay 20-fold (1.30 log units) below the measured number, outside the stated range (above it).
By their numbers in this assay, from the lowest: compound 2; then compound 1; then compound 3.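

Quinolin-3-yl on this aromatic carbon costs far more than any earlier exchange suggested: the change brings a 30-fold higher number from compound 2 to compound 3 (1.48 log units; beyond the scatter) and also a 6.0-fold higher number from compound 1 to compound 3 (0.78 log units; beyond the scatter). The position therefore does not merely respond to its substituent, since one exchange here can weaken inhibition well past the level seen with trifluoromethyl, leaving quinolin-3-yl the weakest of the three groups. Nothing available explains this loss.

From the compounds shown here alone, whether a single phenyl ring would behave like quinolin-3-yl stays open. So does whether an amine or a methoxy group on this carbon would give a lower number than methylsulfanyl.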